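This account rests on a few compounds, and the source may have more. Where it says the series, first, only, none or still open, it means among the compounds named here.

Compound 1 `CCC(C)N(C(=O)[C@H](CC(=O)OC)NC(=O)OC(C)(C)C)C1(C(=O)NCc2ccccc2)CCN(Cc2ccccc2)CC1` gives 84000 nM in an ADME assay on MDCK cells (Canis lupus familiaris) for cytotoxicity, read by microscopy, with a stated time of 72 h; on this read-out lower numbers stand for higher toxicity in this test and higher numbers for lower toxicity in this test. Compound 2 `COC(=O)C[C@H](NC(=O)OC(C)(C)C)C(=O)N(Cc1ccc(C)cc1)C1(C(=O)NCc2ccccc2)CCN(Cc2ccccc2)CC1` gives > 100000 nM in this assay, and that figure is a limit of the measurement rather than a number. The step of an at least 1.1-fold higher number from compound 1 to compound 2 (0.07 log units; that floor lies within the scatter) is known only as a floor owing to the limit of > 100000 nM in this assay, at which 1 of the 2 values shown sits. Compound 3 `COC(=O)C[C@H](NC(=O)OC(C)(C)C)C(=O)N(Cc1ccc(C(F)(F)F)cc1)C1(C(=O)NCc2ccccc2)CCN(Cc2ccccc2)CC1` is not yet measured; it differs from compound 2 by trifluoromethyl in place of methyl on an aromatic carbon. Going by the values given here, no measured step involves this change, so no movement beyond the scatter is expected. Compound 3 is therefore expected to stay near the limit, with a step of a number no higher from compound 2 to compound 3 (the limit leaves the size open) and an estimate of 100000 nM, ranging from 40000 nM to 200000 nM.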

Compound 3, minimum cytotoxic concentration: 84000 nM
For compound 3 the middle estimate is 1.2-fold (0.08 log units) above the measured one; the measured number falls inside the stated range.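

Trifluoromethyl in place of methyl on the aromatic carbon gives an at least 1.1-fold lower number from compound 2 to compound 3 (0.07 log units; that floor lies within the scatter) in this assay. From the compounds shown here alone, compound 2 carries a limit and not a number, so the true size of this step stays unknown because of that limit: the limit of > 100000 nM in this assay, at which 1 of the 3 values shown sits. At the amide-type nitrogen, 4-(trifluoromethyl)benzyl in place of sec-butyl gives no change at the digits printed from compound 1 to compound 3 (within the scatter), so these two groups read alike here. Still open, going by these compounds, is how an amine or a carboxylic acid at this place on the aromatic ring would read, and whether any change there moves the number beyond the scatter.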